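Swapping the aryl group on a flexible ether linker

The source may report more compounds than this note shows. Statements on the series, on what has been measured and on what is new or still open speak of the compounds shown alone.

Compound 1, `CCCCC(Sc1ccc(OCCCOc2ccc(Cl)cc2OC)cc1)C(=O)O`, gives > 10000 nM in an assay for inhibition of Polyunsaturated fatty acid 5-lipoxygenase (Homo sapiens), read by HPLC, with a stated time of 10 min; on this read-out higher numbers stand for weaker inhibition and lower numbers for stronger inhibition; this is a limit of the assay, not a number.
Compound 2, `CCCCC(Sc1ccc(OCCCOc2cccc(C(F)(F)F)c2)cc1)C(=O)O`, gives 9800 nM in this assay.

Going by the values given here, compound 2 stands as the only compound with an actual number in this assay. The value of compound 1 is a limit (the limit of > 10000 nM in this assay, at which 1 of the 2 values shown sits). Compound 3, `CCCCC(Sc1ccc(OCCCOc2ccc3ncccc3c2)cc1)C(=O)O`, differs from compound 2 in one place: quinolin-6-yl in place of 3-(trifluoromethyl)phenyl on an oxygen on a saturated carbon. Among the compounds with values here, the only measured step, an at least 1.0-fold lower number from compound 1 to compound 2 (0.00 log units; that floor lies within the scatter), changed the group on the same oxygen, and the two values sit within the usual scatter of each other. That step begins at a limit (the limit of > 10000 nM in this assay, at which 1 of the 2 values shown sits), so it gives only a loose guide. The change to compound 3 is therefore expected to move the number by little, a 1.2-fold lower number from compound 2 to compound 3 (0.09 log units; within the scatter), with no clear direction. Compound 3 is estimated at 8000 nM, with a range from 2500 nM to 30000 nM.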

Compound 3, half-maximal inhibitory concentration: > 10000 nM
Compound 3: no number, only a limit; the forecaster's own chance of this, stated with the estimate: 40%; middle value at least 1.2-fold (0.09 log units) from the limit.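

Compound 3, with quinolin-6-yl on this oxygen, also ends at a limit of the assay and not at a number: the limit of > 10000 nM in this assay, at which 2 of the 3 values shown sit. Going by these compounds alone, the one readable step is only a floor, an at least 1.0-fold higher number from compound 2 to compound 3 (0.00 log units; that floor lies within the scatter), so this change shows no lowering of the number in this assay, and how far the number may have risen cannot be told. The step between the two compounds that both sit at the limit cannot be read, so across these three groups, which include both one-ring and two-ring aryl groups, none gives a number clearly separated from the limit.

Still open, as far as these compounds go, is whether any other group on this oxygen, such as a plain phenyl or a phenyl carrying a carboxylic acid, would bring the number well under the limit. Also open, from the compounds shown here alone, is whether a longer chain in place of the saturated linker would do so.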